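Replacing 2,2-difluoroethoxy with 2-methoxyethoxy in compound 1

This account rests on a few compounds, and the source may have more. Where it says the series, first, only, none or still open, it means among the compounds named here.

Measured in an ADME assay on microsomes from liver (Mus musculus) for metabolic stability, read by LC-MS, with a stated time of 4 h, tested at 1 uM (a lower number here means slower removal, a higher number faster removal of the compound), each entry a limit and not a number:
compound 1 `Cc1cc(CNC(=O)Nc2cc(Cl)nc(OCC(F)F)c2)nnc1-c1cn(C)nc1C(F)(F)F`: < 167 mL/min/kg
compound 2 `CCOc1cc(NC(=O)NCc2cc(C)c(-c3cn(C)nc3C(F)(F)F)nn2)cc(C#N)n1`: < 105 mL/min/kg
compound 3 `CCOc1cc(NC(=O)NCc2cc(C)c(-c3cn(C)nc3C(F)(F)F)nn2)cc(C)n1`: < 58.4 mL/min/kg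

None of the three compounds has a measured number for clearance in this assay. Compound 1 stands only at a limit, < 167 mL/min/kg.

Compound 4 `COCCOc1cc(NC(=O)NCc2cc(C)c(-c3cn(C)nc3C(F)(F)F)nn2)cc(Cl)n1` keeps the core of compound 1 and differs from it in one place: methoxymethyl in place of difluoromethyl on a saturated chain carbon bound to an oxygen on an aromatic ring. Read one bond further out, 2,2-difluoroethoxy gives way to 2-methoxyethoxy.

The only measured step among these compounds is a step that the two limits leave unreadable from compound 2 to compound 3. That step is methyl in place of cyano on an aromatic carbon, which is a different change from this one, and it offers no size to carry over. With no readable step on this change, no step beyond the usual scatter is expected in this assay, and no direction can be assigned.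

The expected outcome for the change is a step that the limit leaves unreadable from compound 1 to compound 4. All three measured compounds came back as limits, so compound 4 is also likely to be reported as a limit rather than a number.

For compound 4 the estimated clearance is 60 mL/min/kg, with an expected range of 20 mL/min/kg to 150 mL/min/kg.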

Compound 4, clearance: 317 mL/min/kg
Beside the measured number, compound 4's estimate is 5.3-fold (0.72 log units) below it; the whole stated range lies below it.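

In this assay, compound 4 carries the only measured number among the compounds shown, which makes this change the one step whose direction can be read: replacing 2,2-difluoroethoxy with 2-methoxyethoxy gives an at least 1.8-fold higher number from compound 1 to compound 4 (0.27 log units; that floor lies within the scatter). The earlier compounds shown here, all reported as limits, could not show that a swap of difluoromethyl for methoxymethyl, on a saturated chain carbon bound to an oxygen on an aromatic ring, can go with faster removal, although the floor of the step alone does not clear the scatter. Only that floor can be stated, and the true step may be larger, since the comparison starts from a limit and not a number: the limit of < 167 mL/min/kg in this assay, at which 1 of the 4 values shown sits.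

From the compounds shown here alone, the real size of the step therefore stays open, and the step between compound 2 and compound 3 cannot be read at all. The compounds shown also leave open how a 2-hydroxyethoxy chain or a longer chain such as 3-methoxypropoxy would read in the same place on the core of compound 1.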